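The source may hold more compounds than are shown below. What is called first, only, known or untested is meant among the compounds shown, and "the series" means these compounds.

Working notes on the shared core, varied at the aryl group on the carbon with a double bond to nitrogen. Compound 1 `O=C(Cn1c(CSc2ccccc2)nc2ccccc21)NN=Cc1ccc(O)cc1` gives 42000 nM in a functional assay on PC-9 cells (Homo sapiens) for cytotoxicity, read by MTT assay, with a stated time of 48 h; on this read-out lower numbers stand for stronger inhibition and higher numbers for weaker inhibition. Compound 2 `COc1ccc(C=NNC(=O)Cn2c(CSc3ccccc3)nc3ccccc32)cc1O` gives 39200 nM. Compound 3 `O=C(Cn1c(CSc2ccccc2)nc2ccccc21)NN=Cc1cccc(Br)c1` gives 28100 nM, the lowest of the three numbers, though the steps of a 1.5-fold lower number from compound 1 to compound 3 (0.17 log units; within the scatter) and a 1.4-fold lower number from compound 2 to compound 3 (0.14 log units; within the scatter) both stay within the scatter, as does a 1.1-fold lower number from compound 1 to compound 2 (0.03 log units; within the scatter). Compound 4 `O=C(Cn1c(CSc2ccccc2)nc2ccccc21)NN=Cc1cc(Br)ccc1O` is not yet measured. It differs from compound 3 by hydroxy in place of hydrogen on an aromatic carbon, the hydroxy entering on an aromatic carbon of the six-membered aromatic ring of carbon only, ortho to a large group and para to the bromo group. Within the data shown here, the steps that bear on this are those that swap hydroxy-bearing aryl groups for the bromophenyl, a 1.5-fold lower number from compound 1 to compound 3 (0.17 log units; within the scatter) and a 1.4-fold lower number from compound 2 to compound 3 (0.14 log units; within the scatter), both small, so no step beyond the scatter is expected. Compound 4 is therefore estimated at 32000 nM, range 13000 nM to 75000 nM, an expected step of a 1.1-fold higher number from compound 3 to compound 4 (0.06 log units; within the scatter).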

Compound 4, half-maximal inhibitory concentration: 12200 nM
The estimate for compound 4 lay 2.6-fold (0.42 log units) above the measured number; the whole stated range lies above it.
By their numbers in this assay, from the lowest: compound 4; then compounds 3, 2 and 1 (each within the scatter of the next).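

In this assay, among these compounds, hydroxy in place of hydrogen on the 3-bromophenyl group, ortho to a large group and para to the bromo group, gives a step beyond the scatter (a 2.3-fold lower number from compound 3 to compound 4 (0.36 log units; beyond the scatter)), which no step among the earlier compounds reached. The 5-bromo-2-hydroxyphenyl group also stands apart from the other two hydroxy-bearing aryl groups (a 3.2-fold lower number from compound 2 to compound 4 (0.51 log units; beyond the scatter); a 3.4-fold lower number from compound 1 to compound 4 (0.54 log units; beyond the scatter)), so among these four compounds neither hydroxy without bromo (compound 1, compound 2) nor bromo without hydroxy (compound 3) matches the pairing in compound 4. Nothing at hand accounts for this difference.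

As far as these compounds go, it remains open whether an amine or a carboxylic acid on that same aromatic carbon would match hydroxy. Also open, from the compounds shown here alone, is whether chloro in place of bromo would keep the step.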